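Ring chlorination on the benzylsulfanyl arm: measured and expected

A few compounds are considered here, and "the series" means these few. Any claim that something is new, unique, unknown or untested is made for them only; others in the source may bear on it.

Measured so far, in a functional assay on the whole organism (artery, strain albino) with Rattus norvegicus as the target, with a stated time of 360 min, at a dose of 10 mg/kg by the oral route; a lower number here means less inhibition, a higher number more inhibition at the dose given (going by the name of the read-out):
compound 1 `CC1=C(C(=O)Nc2ccc(Br)cc2)C(c2ccc(Cl)cc2Cl)N=C(SCc2ccccc2)N1`: compound 1 gives 24.2%
compound 2 `CC1=C(C(=O)Nc2ccc(Br)cc2)C(c2ccc(Cl)cc2Cl)N=C(SCc2ccc(Cl)cc2)N1`: compound 2 gives 39.7%
compound 3 `CC1=C(C(=O)Nc2ccc([N+](=O)[O-])cc2)C(c2ccc(Br)cc2)N=C(SCc2ccccc2)N1`: compound 3 gives 37.6%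

Compound 2 differs from compound 1 by chloro in place of hydrogen on an aromatic carbon. This one change reads as a number 15.5 percentage points higher from compound 1 to compound 2 (beyond the scatter) in this assay.

Compound 3 carries a different core from compound 1; the difference between the two cores is not broken down here. Against compound 2, compound 3 is within the scatter, so no order between the two is claimed. Against compound 1, compound 3 stands beyond the scatter.

Compound 4 `CC1=C(C(=O)Nc2ccc([N+](=O)[O-])cc2)C(c2ccc(Br)cc2)N=C(SCc2ccccc2Cl)N1` is not yet measured. It differs from compound 3 by chloro in place of hydrogen on an aromatic carbon. Among the compounds with values here, this is the same kind of change as the one from compound 1 to compound 2, but not the same: in compound 2 the chloro sits para to a large group, in compound 4 ortho to a large group, so the earlier step is a guide only, not a template. Within the data shown here, the series holds no other ortho example on this arm, and no second core on which the para change was tried.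

From compound 3 to compound 4 a step of a number 8.4 percentage points higher from compound 3 to compound 4 (within the scatter) in this assay is expected, resting on compound 1 to compound 2 reading a number 15.5 percentage points higher from compound 1 to compound 2 (beyond the scatter) and tempered for the changed place. Compound 4 is therefore estimated at 46%, with a range from 30% to 60%.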

Compound 4, a percentage reported as inhibition, in the whole organism at one dose (the size of the read-out at that dose, not a potency): 13.9%
Compound 4: middle estimate off by 32.1 percentage points, on the high side; measured number outside the range, below it.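

In this assay, the chloro on the benzylsulfanyl arm, here giving (2-chlorobenzyl)sulfanyl, reads as a number 23.7 percentage points lower from compound 3 to compound 4 (beyond the scatter). Set beside the earlier step, the sign reverses, so in this series the addition of a chloro to this arm does not carry from one core to the other as a fixed increment, nor even in a fixed direction: the same change on two cores in this assay, a number 15.5 percentage points higher (beyond the scatter) from compound 1 to compound 2 and a number 23.7 percentage points lower (beyond the scatter) from compound 3 to compound 4, 39.2 percentage points apart, beyond the scatter of two such steps

What this does not show is which difference lies behind the reversal: the core changes between the two steps, and so does the place of the chloro, which in compound 4 is ortho to a large group and in compound 2 is elsewhere on the ring, and two steps alone cannot separate these or give a rule for the series.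

Open, on these data alone, are the 2-chlorobenzyl arm on the core of compound 1 and the chloro placement of compound 2 on the core of compound 3, the two pairings that would tell core from place. Also open, as far as these compounds go, is how the arm responds to other groups on the same ring, such as a methoxy group or an amine, or to a longer chain between the sulfur and the ring.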